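Three amides around a shared core, and a fourth to come

The compounds below may be only part of what the source reports. "The series", "measured", "known", "first", "only" and "open" are said of these compounds alone.

Compound 1 `COc1ccc(CN(C(C)=O)c2cc(OC)c(OC)c(OC)c2)cc1O`: 270 nM
Compound 2 `COc1ccc(CN(C(=O)CCCCCl)c2cc(OC)c(OC)c(OC)c2)cc1O`: 220 nM
Compound 3 `COc1ccc(CN(C(=O)C=C(C)C)c2cc(OC)c(OC)c(OC)c2)cc1O`: 290 nM

Of the compounds shown here, three have been measured in a functional assay on HCT-116 cells (Homo sapiens) for inhibition, read by MTT assay, with a stated time of 48 h (a lower number here means a stronger inhibitor, a higher number a weaker inhibitor), and they sit close together. Compound 3 gives the highest of the three numbers, but the steps that lead to it are small: a 1.1-fold higher number from compound 1 to compound 3 (0.03 log units; within the scatter) and a 1.3-fold higher number from compound 2 to compound 3 (0.12 log units; within the scatter), both within the scatter. Compound 1 and compound 2 are likewise separated by a 1.2-fold lower number from compound 1 to compound 2 (0.09 log units; within the scatter), within the scatter. So far, changing the group on the carbonyl carbon has not moved the number beyond the scatter.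

Compound 4 `C=CC(=O)N(Cc1ccc(OC)c(O)c1)c1cc(OC)c(OC)c(OC)c1` continues in the same place. The difference from compound 3 is vinyl in place of 2-methylprop-1-en-1-yl on a carbonyl carbon.

Going by the values given here, the steps that bear on this are those on the carbonyl carbon: from compound 1 to compound 3, a 1.1-fold higher number from compound 1 to compound 3 (0.03 log units; within the scatter), and from compound 2 to compound 3, a 1.3-fold higher number from compound 2 to compound 3 (0.12 log units; within the scatter). Among the compounds with values here, both were within the scatter, so the expectation for compound 4 is a step of about a 1.2-fold lower number from compound 3 to compound 4 (0.06 log units; within the scatter), with no direction that the numbers so far would support beyond the scatter. Compound 4 is therefore estimated at 250 nM, in a range from 120 nM to 520 nM.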

Compound 4, half-maximal inhibitory concentration: 98 nM
Estimate against measurement, compound 4: 2.6-fold (0.41 log units) above, and the stated range ends above it.
By their numbers in this assay, from the lowest: compound 4; then compounds 2, 1 and 3 (each within the scatter of the next).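

In this assay the group on the carbonyl carbon turns out to be able to move the number beyond the scatter, which the earlier compounds had not shown: vinyl in place of 2-methylprop-1-en-1-yl gives (a 3.0-fold lower number from compound 3 to compound 4 (0.47 log units; beyond the scatter)), vinyl in place of 4-chlorobutyl gives (a 2.2-fold lower number from compound 2 to compound 4 (0.35 log units; beyond the scatter)), and vinyl in place of methyl gives (a 2.8-fold lower number from compound 1 to compound 4 (0.44 log units; beyond the scatter)), all modest steps. A double bond outside aromatic rings does not by itself go with the lower number, since 2-methylprop-1-en-1-yl carries one as well and compound 3 stays within the scatter of compound 1 and compound 2. A small group does not by itself go with it either, since compound 1 with its methyl stays within the scatter of compound 2 and compound 3, so among these four compounds the lower number belongs to vinyl alone.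

The compounds shown leave open how a prop-1-en-1-yl group or an ethynyl group on the same carbonyl carbon would read. Nothing available here bears on why vinyl stands apart from the other three groups.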